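A few compounds are considered here, and "the series" means these few. Any claim that something is new, unique, unknown or untested is made for them only; others in the source may bear on it.

For the measured compounds named here, compound 2 `CCOC(=O)c1c(N)sc(-c2ccc(Cl)cc2)c1-c1cccc(C(F)(F)F)c1` holds the only number obtained in a functional assay on CHO-K1 cells for agonist activity at adenosine receptor A1 (Homo sapiens), read by GTPgammaS binding (on this read-out lower numbers stand for an effect already at smaller amounts and higher numbers for an effect only at larger amounts of compound), where compound 2 gives 6.6 uM. Compound 1 `CCOC(=O)c1c(N)sc(-c2ccc([N+](=O)[O-])cc2)c1-c1cccc(C(F)(F)F)c1` reaches only a limit in this assay, > 10 uM. The step of an at least 1.5-fold lower number from compound 1 to compound 2 (0.18 log units; that floor lies within the scatter) therefore rests on that limit, (the limit of > 10 uM in this assay, at which 1 of the 2 values shown sits). Compound 3 `CCOC(=O)c1c(N)sc(-c2ccc(C(F)(F)F)cc2)c1-c1cccc(C(F)(F)F)c1` differs from compound 2 by trifluoromethyl in place of chloro on an aromatic carbon. Going by the values given here, no measured step exchanges chloro for trifluoromethyl. Among the compounds with values here, since the only known step, an at least 1.5-fold lower number from compound 1 to compound 2 (0.18 log units; that floor lies within the scatter), is small and bounded by a limit, the step of no change at the digits printed from compound 2 to compound 3 (within the scatter) is expected to stay within the scatter. Compound 3 is estimated at 6.6 uM, with a range from 2.5 uM to 15 uM.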

Compound 3, concentration for half-maximal effect: > 10 uM
Compound 3 ended at the assay's limit; the forecaster's own chance of this, stated with the estimate: 30%; middle value at least 1.5-fold (0.18 log units) from the limit.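

Trifluoromethyl in place of chloro gives an at least 1.5-fold higher number from compound 2 to compound 3 (0.18 log units; that floor lies within the scatter), so this exchange, like the one from nitro, has a floor that does not leave the scatter. The step between compound 1 and compound 3 cannot be read, since both values are limits. Among the three groups, chloro alone gives a number rather than a limit in this assay: the limit of > 10 uM in this assay, at which 2 of the 3 values shown sit.

As far as these compounds go, how far compound 1 and compound 3 actually lie from compound 2 stays open. Also open, from the compounds shown here alone, is whether an amine or a carboxylic acid at this place would give a number.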